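Two Fluorinated Benzyl Groups and a Third to Be Tested

The compounds below may be only part of what the source reports. "The series", "measured", "known", "first", "only" and "open" are said of these compounds alone.

Two compounds share one core and differ only in the group hanging from the saturated chain carbon bound to an aromatic nitrogen. Compound 1 `CCCn1c(=O)c2nc(-c3cnn(Cc4c(F)cc(F)cc4F)c3)[nH]c2n(CCC)c1=O` gives 650 nM in an in vitro assay on HEK293 cells for displacement of a labelled ligand from adenosine receptor A2b (Homo sapiens) (on this read-out lower numbers stand for stronger inhibition and higher numbers for weaker inhibition), and compound 2 `CCCn1c(=O)c2nc(-c3cnn(Cc4ccc(F)cc4F)c3)[nH]c2n(CCC)c1=O` gives 700 nM in the same assay. Among the compounds with values here, compound 2 stands at the higher of these two numbers, but its only neighbour, compound 1, lies within the scatter: the step of a 1.1-fold higher number from compound 1 to compound 2 (0.03 log units; within the scatter) is too small to read as a real change. Compound 3 `CCCn1c(=O)c2nc(-c3cnn(Cc4ccc(F)c(C(F)(F)F)c4)c3)[nH]c2n(CCC)c1=O` carries a different ring: 4-fluoro-3-(trifluoromethyl)phenyl in place of 2,4-difluorophenyl on a saturated chain carbon bound to an aromatic nitrogen. Within the data shown here, no measured step covers such a swap; the single step available, the loss of one fluoro, produced nothing beyond the scatter, so no clear direction can be drawn from it. Compound 3 is therefore expected to show a step of no change at the digits printed from compound 2 to compound 3 (within the scatter), that is, a value estimated at 700 nM with a range from 250 nM to 2000 nM.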

Compound 3, inhibition constant: 640 nM
The estimate for compound 3 lay 1.1-fold (0.04 log units) above the measured number; low and high end bracket the measured number.
By their numbers in this assay, from the lowest: compounds 3, 1 and 2 (each within the scatter of the next).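

In this assay, putting 4-fluoro-3-(trifluoromethyl)phenyl on a saturated chain carbon bound to an aromatic nitrogen gives two steps within the scatter (in place of 2,4-difluorophenyl, a 1.1-fold lower number from compound 2 to compound 3 (0.04 log units; within the scatter)) and (in place of 2,4,6-trifluorophenyl, a 1.0-fold lower number from compound 1 to compound 3 (0.01 log units; within the scatter)). Until now this place had been probed only by the loss of one fluoro, whereas this change brings a trifluoromethyl group and raises the group from 8 to 11 heavy atoms, still with no change beyond the scatter. No supporting measurement is available to explain why these groups read alike.

All three groups shown are fluorinated phenyl rings. Still open, on these data alone, is whether the same flat reading would hold for plain phenyl, or for a phenyl ring carrying an amine or a carboxylic acid.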